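Swapping 3-chlorophenyl for 4-fluorophenyl on a weak series

A few compounds are considered here, and "the series" means these few. Any claim that something is new, unique, unknown or untested is made for them only; others in the source may bear on it.

- compound 1 `Cc1ccccc1NNC(=O)c1cccc(NS(=O)(=O)c2cnc(O)nc2O)c1` reads > 20000 nM as a limit
- compound 2 `Cc1cccc(NNC(=O)c2cccc(NS(=O)(=O)c3cnc(O)nc3O)c2)c1` reads > 20000 nM as a limit
- compound 3 `O=C(NNc1cccc(Cl)c1)c1cccc(NS(=O)(=O)c2cnc(O)nc2O)c1` reads 8040 nM as a number

In a functional assay on OVCAR-3 cells (Homo sapiens) for antiproliferative activity, read by MTT assay, with a stated time of 24 h (on this read-out higher numbers stand for weaker inhibition and lower numbers for stronger inhibition), compound 3 is the only one of the three with a true number, at 8040 nM on this scale. The other two stop at the limit of > 20000 nM in this assay, at which 2 of the 3 values shown sit, and give no number.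

Compound 4 `O=C(NNc1ccc(F)cc1)c1cccc(NS(=O)(=O)c2cnc(O)nc2O)c1` keeps the shared core and carries 4-fluorophenyl in place of 3-chlorophenyl on an amine nitrogen. The difference in full is 4-fluorophenyl in place of 3-chlorophenyl on an amine nitrogen and the rest of the molecule stays the same.

Among the compounds with values here, no measured step puts fluorine on the ring. The closest evidence is an at least 2.4-fold lower number from compound 1 to compound 3 (0.39 log units; beyond the scatter) and also an at least 2.4-fold lower number from compound 2 to compound 3 (0.39 log units; beyond the scatter) and both of these steps bring in 3-chlorophenyl. The remaining step, a step that the two limits leave unreadable from compound 1 to compound 2 in full, has no readable size. Within the data shown here, compound 4 gives up the group that came with the only number here, so a modest move back towards weaker inhibition seems likely. In this assay the expected change is a 2.2-fold higher number from compound 3 to compound 4 (0.35 log units; beyond the scatter) and this estimate is uncertain, with a real chance that only a limit is reported. For compound 4 the estimate is 18000 nM with an expected range from 7000 nM to 35000 nM around it.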

Compound 4, half-maximal inhibitory concentration: > 20000 nM
Compound 4: only a limit was reported; the forecaster's own chance of this, stated with the estimate: 50%; middle value at least 1.1-fold (0.04 log units) away from the limit.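

In this assay compound 4 gives > 20000 nM, which is a limit and not a number. The change on the amine nitrogen comes with an at least 2.4-fold higher number from compound 3 to compound 4 (0.39 log units; beyond the scatter), so 4-fluorophenyl does not keep the activity seen with 3-chlorophenyl, and among the four groups shown at this position, only 3-chlorophenyl gives a true number. The steps linking compound 4 to compound 1 and compound 2 cannot be read, which leaves a single true number to anchor the whole comparison, and most of the set sits at one ceiling: the limit of > 20000 nM in this assay, at which 3 of the 4 values shown sit.

The step from 3-chlorophenyl to 4-fluorophenyl changes both the halogen and its place on the ring, so the compounds shown cannot say which of the two matters; 3-fluorophenyl and 4-chlorophenyl would separate them. Also open, going by these compounds, is whether any other group at this position, such as 3-bromophenyl or 3,4-dichlorophenyl, would give a stronger number than compound 3 or would fall back to the limit.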